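A few compounds are considered here, and "the series" means these few. Any claim that something is new, unique, unknown or untested is made for them only; others in the source may bear on it.

Of the compounds shown here, three that share one core have been measured in a functional assay on B16-F10 cells (Mus musculus) for antiproliferative activity, read by MTT assay, with a stated time of 48 h; on this read-out higher numbers stand for weaker inhibition and lower numbers for stronger inhibition. Compound 1 `COc1ccc(/C=C/c2cc(OC)cc(OC)c2/C=C/C(=O)c2ccc(Cl)cc2)cc1` gives 4.9 ug/mL. Compound 2 `COc1ccc(/C=C/c2cc(OC)cc(OC)c2/C=C/C(=O)c2ccccc2)cc1` gives 3.7 ug/mL. Compound 3 `COc1ccc(/C=C/c2cc(OC)cc(OC)c2/C=C/C(=O)c2ccc(C)cc2C)cc1` gives 4 ug/mL, which cannot be told apart from the other two values. The steps leading to it are a 1.1-fold higher number from compound 2 to compound 3 (0.03 log units; within the scatter) and a 1.2-fold lower number from compound 1 to compound 3 (0.09 log units; within the scatter).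

Compound 4 `CCN(CC)c1ccc(C(=O)/C=C/c2c(/C=C/c3ccc(OC)cc3)cc(OC)cc2OC)cc1` has not yet been measured. It has 4-(diethylamino)phenyl in place of 2,4-dimethylphenyl on a carbonyl carbon. The closest guides are the two steps above, which changed the group at this same place, along with the remaining step, a 1.3-fold lower number from compound 1 to compound 2 (0.12 log units; within the scatter). For the measured compounds named here, all three are small, but no measured compound carries 4-(diethylamino)phenyl, so the range must stay wide. No step beyond the scatter is therefore expected in this assay. The estimated step is no change at the digits printed from compound 3 to compound 4 (within the scatter). Compound 4 is expected to give about 4 ug/mL, with an estimated range of 1.8 ug/mL to 8.5 ug/mL.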

Compound 4, half-maximal inhibitory concentration: 8.1 ug/mL
Compound 4: the middle estimate sits 2.0-fold (0.31 log units) below what was measured; low and high end bracket the measured number.
By their numbers in this assay, from the lowest: compounds 2, 3, 1 and 4 (each within the scatter of the next, the first and the last beyond it).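

Until now, the groups on this carbonyl carbon (phenyl, 4-chlorophenyl and 2,4-dimethylphenyl) gave no step beyond the scatter. 4-(Diethylamino)phenyl gives the first such steps, toward weaker inhibition: a 2.0-fold higher number from compound 3 to compound 4 (0.31 log units; beyond the scatter) and a 2.2-fold higher number from compound 2 to compound 4 (0.34 log units; beyond the scatter). For the compounds shown here, the third step, a 1.7-fold higher number from compound 1 to compound 4 (0.22 log units; within the scatter), stays within the scatter, so the change is modest and separates compound 4 from only two of its three neighbours, and nothing measured here explains it.

Still open, from the compounds shown here alone, is whether the nitrogen itself or its two ethyl groups matter, which a 4-aminophenyl or 4-(dimethylamino)phenyl group at this place could help separate. A carboxylic acid on this ring would show whether other groups at this place move the number further.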